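Diaryl ureas on a chloropyrazinylaminomethyl core: a dichlorophenyl step

This account rests on a few compounds, and the source may have more. Where it says the series, first, only, none or still open, it means among the compounds named here.

Measured compounds:
compound 1, `O=C(Nc1ccccc1)Nc1cccc(CNc2nccnc2Cl)c1`, 19800 nM
compound 2, `COc1ccccc1NC(=O)Nc1cccc(CNc2nccnc2Cl)c1`, 10400 nM
compound 3, `O=C(Nc1cccc(Cl)c1)Nc1cccc(CNc2nccnc2Cl)c1`, 6810 nM

In a functional assay on T-24 cells (Homo sapiens) for antiproliferative activity, read by MTT assay, with a stated time of 48 h (a lower number here means a stronger inhibitor, a higher number a weaker inhibitor), compound 1 gives the highest of the three numbers. Its nearest neighbour is compound 2, reached by a 1.9-fold lower number from compound 1 to compound 2 (0.28 log units; within the scatter), and its furthest is compound 3, reached by a 2.9-fold lower number from compound 1 to compound 3 (0.46 log units; beyond the scatter). Compound 2 and compound 3 differ from each other by a 1.5-fold lower number from compound 2 to compound 3 (0.18 log units; within the scatter).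

Compound 4, `O=C(Nc1cccc(CNc2nccnc2Cl)c1)Nc1ccc(Cl)cc1Cl`, has not yet been measured in this assay. It differs from compound 1 as follows: 2,4-dichlorophenyl in place of phenyl on an amide-type nitrogen. Among the measured compounds shown here, the step that bears most directly on it is the one from compound 1 to compound 3, where a single chloro on the terminal phenyl brought a modest lowering. For the measured compounds named here, two chlorines on the same phenyl have no measured precedent, and the modest size of the single-chloro step makes a similar or somewhat larger downward step plausible, rather than none. Compound 4 is therefore expected to give 6500 nM, within 2500 nM to 16000 nM, which means an expected step of a 3.0-fold lower number from compound 1 to compound 4 (0.48 log units; beyond the scatter).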

Compound 4, half-maximal inhibitory concentration: 5740 nM
Beside the measured number, compound 4's estimate is 1.1-fold (0.05 log units) above it, within the range that was stated.
By their numbers in this assay, from the lowest: compounds 4, 3, 2 and 1 (each within the scatter of the next, the first and the last beyond it).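

In this assay, the 2,4-dichlorophenyl group on the amide-type nitrogen also stands clear of the plain phenyl of compound 1 (a 3.4-fold lower number from compound 1 to compound 4 (0.54 log units; beyond the scatter)), so a second chlorinated ring now shows a step beyond the scatter. The second chlorine adds nothing that can be separated from the single-chloro ring (a 1.2-fold lower number from compound 3 to compound 4 (0.07 log units; within the scatter)), and the step from the 2-methoxyphenyl ring also stays inside the scatter (a 1.8-fold lower number from compound 2 to compound 4 (0.26 log units; within the scatter)). Nothing measured here explains these numbers.

The compounds shown leave open how each of the two chlorines of compound 4 contributes on its own. They also leave open whether a trifluoromethyl, a nitrile or an amine on this ring would take the number further than chlorine does.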